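The source may hold more compounds than are shown below. What is called first, only, known or untested is meant among the compounds shown, and "the series" means these compounds.

Measured compounds in a functional assay on HBL-100 cells (Homo sapiens) for inhibition, read by sulforhodamine B assay, with a stated time of 48 h; on this read-out higher numbers stand for weaker inhibition of growth and lower numbers for stronger inhibition of growth:
compound 1 `COC(=O)[C@@]1(C)CCC=C2[C@@H]1CC[C@@H](C)[C@]2(C)Cc1c[nH]c2ccccc12` gives 4500 nM
compound 2 `COC(=O)[C@@]1(C)CCC=C2[C@@H]1CC[C@@H](C)[C@]2(C)Cc1c(C)[nH]c2ccccc12` gives 14000 nM
compound 3 `COC(=O)[C@@]1(C)CCC=C2[C@@H]1CC[C@@H](C)[C@]2(C)Cc1c(C)[nH]c2c(Br)cccc12` gives 27000 nM

Compound 2 stands in the middle of the three numbers: its separation from compound 1 lies beyond the scatter, while its separation from compound 3 lies within it, so compounds 2 and 3 cannot be ordered on this assay.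

Compound 4 `COC(=O)[C@@]1(C)CCC=C2[C@@H]1CC[C@@H](C)[C@]2(C)Cc1c(C=O)[nH]c2ccccc12` is the next candidate. Its change from compound 2 is formyl in place of methyl on an aromatic carbon.

Within the data shown here, two measured steps bear on this carbon and its neighbourhood. Among the measured compounds shown here, the step of a 3.1-fold higher number from compound 1 to compound 2 (0.49 log units; beyond the scatter) is the only one that alters the group at this carbon, and it runs toward weaker inhibition. The step of a 1.9-fold higher number from compound 2 to compound 3 (0.29 log units; within the scatter) changes a different aromatic carbon and stays within the scatter. For the measured compounds named here, no measured compound carries formyl, so the direction for compound 4 rests on weak ground; since methyl leaves and a small acceptor-bearing group enters, a step near zero is expected, given as a 1.2-fold lower number from compound 2 to compound 4 (0.07 log units; within the scatter). Compound 4 is therefore estimated at 12000 nM, with a range from 3500 nM to 40000 nM.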

Compound 4, concentration for 50% growth inhibition: 7500 nM
Beside the measured number, compound 4's estimate is 1.6-fold (0.20 log units) above it; the range from low to high includes it.
By their numbers in this assay, from the lowest: compounds 1, 4, 2 and 3 (each within the scatter of the next, the first and the last beyond it).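

In this assay, formyl at this aromatic carbon next to the ring nitrogen gives a 1.9-fold lower number from compound 2 to compound 4 (0.27 log units; within the scatter) and, set against hydrogen at the same carbon, a 1.7-fold higher number from compound 1 to compound 4 (0.22 log units; within the scatter), so compound 4 cannot be ordered against either compound. Hydrogen and methyl at this carbon do stand apart, by a 3.1-fold higher number from compound 1 to compound 2 (0.49 log units; beyond the scatter), yet formyl cannot be told from either, so it does not show whether the entering group resembles hydrogen or methyl here. No measurement is available that would explain these steps.

Open, going by these compounds, is whether an amine, a carboxylic acid or a longer chain at this carbon would stay within the scatter of formyl. Among these compounds, also open is whether the bromo step, seen only with methyl at this carbon, would read the same with formyl or hydrogen there.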